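A difluoro-hydroxy chain in place of a methoxyethoxy tail

The compounds below may be only part of what the source reports. "The series", "measured", "known", "first", "only" and "open" are said of these compounds alone.

Compound 1, `CS(=O)(=O)c1nn(Cc2nc3cc(Cl)ccc3n2CCO)c2cnccc12`: > 100000 nM
Compound 2, `COCCOCCn1c(Cn2nc(S(C)(=O)=O)c3ccncc32)nc2cc(Cl)ccc21`: > 100000 nM

In an ADME assay on HEp-2 cells (Homo sapiens) for cytotoxicity, with a stated time of 4 days (on this read-out higher numbers stand for lower toxicity in this test and lower numbers for higher toxicity in this test), compound 1 gives > 100000 nM, which is a limit of the assay. Compound 2 likewise gives > 100000 nM, also a limit. Compound 2 therefore stands at the limit of > 100000 nM in this assay, at which 2 of the 2 values shown sit, and the step that the two limits leave unreadable from compound 1 to compound 2 cannot be sized from the two values. Compound 3, `CS(=O)(=O)c1nn(Cc2nc3cc(Cl)ccc3n2CCC(O)C(F)F)c2cnccc12`, differs from compound 2 by 2,2-difluoro-1-hydroxyethyl in place of 2-methoxyethoxy on a saturated chain carbon, two bonds along the chain from an aromatic nitrogen. Among the compounds with values here, the only measured step, from compound 1 to compound 2, touches the same chain and is unreadable, so it gives no direction for the present change; both measured compounds sit at the limit. Compound 3 is therefore expected to remain at or near that limit in this assay, with a step of a number no higher from compound 2 to compound 3 (the limit leaves the size open) that is not expected to reach beyond the scatter. The estimate for compound 3 is 100000 nM, ranging from 40000 nM to 300000 nM.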

Compound 3, half-maximal cytotoxic concentration: > 100000 nM
Compound 3 was reported as a limit; the forecaster's own chance of this, stated with the estimate: 80%; the middle value lies on the limit itself.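

With compound 3 also reported as a limit, no step among compound 1, compound 2 and compound 3 can be read: the limit of > 100000 nM in this assay, at which 3 of the 3 values shown sit.

The compounds shown leave open whether these chains on the shared core differ from one another at all in this assay.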